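Pyridin-2-yl for 1,3-thiazol-2-yl on a Sulfonamide Nitrogen

This account rests on a few compounds, and the source may have more. Where it says the series, first, only, none or still open, it means among the compounds named here.

Measured compounds:
compound 1, `CS(=O)(=O)c1cc2ccc(Nc3ccccc3)cc2c(O)c1/N=N/c1ccc(-c2ccc(/N=N/c3ccc(O)c(C(=O)O)c3)cc2)cc1`, 49000 nM
compound 2, `O=C(O)c1c(O)c(/N=N/c2ccc(S(=O)(=O)Nc3nccs3)cc2)cc2ccccc12`, 30000 nM

Both compounds were tested in an assay for inhibition of PH domain leucine-rich repeat-containing protein phosphatase 2 (Homo sapiens); on this read-out lower numbers stand for stronger inhibition and higher numbers for weaker inhibition. In this read-out compound 1 gives 49000 nM, and compound 2 gives 30000 nM. Of the two numbers, compound 2 has the lower one, but its gap to compound 1 lies within the scatter of repeated measurements, so the two cannot be told apart with confidence. For the measured compounds named here, no pair of measured compounds differs in only one place, and no single structural step has therefore been measured.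

Compound 3, `O=C(O)c1c(O)c(/N=N/c2ccc(S(=O)(=O)Nc3ccccn3)cc2)cc2ccccc12`, is not yet measured. It differs from compound 2 in one place: pyridin-2-yl in place of 1,3-thiazol-2-yl on a sulfonamide nitrogen. Compound 1 and compound 2 differ in several places at once, and they show nothing about this particular change. Going by the values given here, with no measured step to lean on, the expectation is that compound 3 behaves much like compound 2, with a step of no change at the digits printed from compound 2 to compound 3 (within the scatter) that is not expected to go beyond the scatter. Compound 3 is estimated at 30000 nM, with a range from 10000 nM to 90000 nM.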

Compound 3, half-maximal inhibitory concentration: 34000 nM
Beside the measured number, compound 3's estimate is 1.1-fold (0.05 log units) below it, and the stated range covers the measured number.
By their numbers in this assay, from the lowest: compounds 2, 3 and 1 (each within the scatter of the next).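

In this assay, pyridin-2-yl in place of 1,3-thiazol-2-yl on the sulfonamide nitrogen gives a 1.1-fold higher number from compound 2 to compound 3 (0.05 log units; within the scatter), the first single-place step available in this series. This read-out therefore does not distinguish a five-membered aromatic ring with two hetero atoms from a six-membered aromatic ring with one hetero atom at this position, even though the sulfur leaves, the heavy-atom count differs and the hydrogen-bond acceptor count differs. This holds for this one pair on the shared core, and nothing available explains why the two rings read alike.

The compounds shown leave open whether an aromatic ring on the sulfonamide nitrogen matters at all, since a small group such as methyl, or a phenyl ring with no hetero atom, could still give a number clearly different from those of the two rings compared here. They also leave open whether the same insensitivity would hold elsewhere on the core, for instance if the carboxylic acid were replaced by a methyl ester or a primary amide.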